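This account rests on a few compounds, and the source may have more. Where it says the series, first, only, none or still open, it means among the compounds named here.

Compounds measured in a functional assay on MCF7 cells (Homo sapiens) for cytotoxicity, read by MTT assay, with a stated time of 72 h; a lower number here means a stronger inhibitor, a higher number a weaker inhibitor:
- compound 1, `CCCCCCCCCCCCCCNc1nc(SCc2ccc(C(F)(F)F)cc2)nc2ccccc12`: in this assay compound 1 gives > 50000 nM, which is a limit of the assay and not a number.
- compound 2, `FC(F)(F)c1ccc(CSc2nc(Nc3ccccc3)c3ccccc3n2)cc1`: in this assay compound 2 gives 44000 nM.
- compound 3, `Cc1ccccc1Nc1nc(SCc2ccc(C(F)(F)F)cc2)nc2ccccc12`: in this assay compound 3 gives 37500 nM.

Compound 3 stands at the low end of the two numbers, with compound 2 nearest; the step of a 1.2-fold lower number from compound 2 to compound 3 (0.07 log units; within the scatter) lies within the scatter, so the two are not separated. The value of compound 1 sits at the limit of > 50000 nM in this assay, at which 1 of the 3 values shown sits.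

Compound 4, `Cc1ccc(Nc2nc(SCc3ccc(C(F)(F)F)cc3)nc3ccccc23)cc1`, differs from compound 3 only by 4-methylphenyl in place of 2-methylphenyl on a nitrogen on an aromatic ring. For the measured compounds named here, no measured step moves a methyl from one place to another on that ring; the one step that touches it, a 1.2-fold lower number from compound 2 to compound 3 (0.07 log units; within the scatter), adding a methyl, stayed within the scatter. On this evidence no step beyond the scatter is expected in this assay, and the estimated step is a 1.1-fold higher number from compound 3 to compound 4 (0.03 log units; within the scatter). Compound 4 is therefore expected to give about 40000 nM, in a range from 20000 nM to 75000 nM.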

Compound 4, half-maximal inhibitory concentration: > 50000 nM
Compound 4 gave a limit, no number; the forecaster's own chance of this, stated with the estimate: 30%; at least 1.2-fold (0.09 log units) between middle value and limit.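

In this assay, compound 4 gives > 50000 nM, which is a limit of the assay and not a number. Moving the methyl, 4-methylphenyl in place of 2-methylphenyl on a nitrogen on an aromatic ring, gives an at least 1.3-fold higher number from compound 3 to compound 4 (0.12 log units; that floor lies within the scatter), and adding it to the phenyl group gives an at least 1.1-fold higher number from compound 2 to compound 4 (0.05 log units; that floor lies within the scatter), so neither floor separates the compounds. The new information is that an aromatic group on this nitrogen, and not only the long chain of compound 1, can reach the limit: the limit of > 50000 nM in this assay, at which 2 of the 4 values shown sit.

As far as these compounds go, whether the 2-methylphenyl and 4-methylphenyl groups truly differ stays open while one of the pair is known only as a limit. Also open, from the compounds shown here alone, is whether an amine or a carboxylic acid on that aromatic ring would move the number beyond the scatter in this assay.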